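The source may report more compounds than this note shows. Statements on the series, on what has been measured and on what is new or still open speak of the compounds shown alone.

In an ADME assay on MDBK cells (Bos taurus) for cytotoxicity, read by MTT assay, with a stated time of 96 h (a higher number here means that more compound is tolerated, a lower number that less compound is tolerated), compound 2 `C/C(=N\NC(N)=O)c1ccc2[nH]c(-c3ccccc3)nc2c1` reads > 100000 nM, which is a limit of the assay and not a number. Compound 3 `C/C(=N\NC(N)=O)c1ccc2[nH]c(-c3ccc(Cl)cc3)nc2c1` also reads only a limit, > 100000 nM. Compound 4 `C/C(=N\NC(N)=O)c1ccc2[nH]c(-c3ccc(C(F)(F)F)cc3)nc2c1` differs from compound 3 by one change, trifluoromethyl in place of chloro on an aromatic carbon. Within the data shown here, the one measured step at this place, a step that the two limits leave unreadable from compound 2 to compound 3, has no readable size because of the limit of > 100000 nM in this assay, at which 2 of the 3 values shown sit. Compound 1 `C/C(=N\O)c1ccc2[nH]c(-c3ccc(C(F)(F)F)cc3)nc2c1` also carries trifluoromethyl but differs elsewhere in its structure, and it gives 55000 nM. A small step is therefore expected in this assay, possibly towards less compound tolerated. The expected value for compound 4 is 90000 nM, within an estimated range of 40000 nM to 180000 nM. The estimate means an at least 1.1-fold lower number from compound 3 to compound 4 (0.04 log units; that floor lies within the scatter).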

Compound 4, half-maximal cytotoxic concentration: > 100000 nM
Compound 4 gave a limit, no number; the forecaster's own chance of this, stated with the estimate: 60%; at least 1.1-fold (0.04 log units) between middle value and limit.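

In this assay compound 4 reads > 100000 nM, a limit and not a number, so trifluoromethyl joins hydrogen and chloro at this place with no number to tell them apart. The steps from compound 2 and from compound 3 to compound 4 therefore cannot be read, and the reason is this: the limit of > 100000 nM in this assay, at which 3 of the 4 values shown sit. Ureido in place of hydroxy on a double-bonded nitrogen gives an at least 1.8-fold higher number from compound 1 to compound 4 (0.25 log units; that floor lies within the scatter). On these data alone, whether an amine or a carboxylic acid on this aromatic carbon would bring the ureido series under that limit in this assay remains open.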